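The source may hold more compounds than are shown below. What is called first, only, known or untested is meant among the compounds shown, and "the series" means these compounds.

Compound 3 (`CC/C(=C(/c1ccc(/C=C/C(=O)O)cc1)c1ccc2[nH]ncc2c1)c1ccccc1C#N`) stands lowest of the three measured compounds in an ADME assay on the whole organism for pharmacokinetics, with Mus musculus as the target, at a dose of 10 mg/kg by the oral route (a higher number here means more compound in the circulation at the dose given, a lower number less compound in the circulation), with 200 ng.h/mL as its number, while compound 1 (`CC/C(=C(/c1ccc(/C=C/C(=O)O)cc1)c1cccc2[nH]ncc12)c1ccccc1`) reaches 2800 ng.h/mL and compound 2 (`CC/C(=C(/c1ccc(/C=C/C(=O)O)cc1)c1ccc2[nH]ncc2c1)c1ccccc1Cl`) reaches 15000 ng.h/mL in the same test. Compound 4 (`CC/C(=C(/c1ccc(/C=C/C(=O)O)cc1)c1ccc2[nH]ncc2c1)c1ccc(C#N)cc1Cl`) is still unmeasured, and it differs from compound 3 in one group (2-chloro-4-cyanophenyl in place of 2-cyanophenyl on a double-bonded chain carbon bound to a double-bonded chain carbon and a saturated chain carbon): 2-chloro-4-cyanophenyl in place of 2-cyanophenyl on a double-bonded chain carbon bound to a double-bonded chain carbon and a saturated chain carbon.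

For the measured compounds named here, one measured step bears on this change: a 75-fold lower number from compound 2 to compound 3 (1.88 log units; beyond the scatter) when cyano took the place of chloro on an aromatic carbon, a large drop well beyond the scatter. Compound 1 differs from the others in more than one place, so it offers no direct comparison. Going by the values given here, compound 4 brings chloro back but keeps cyano as well, and no measured compound carries the two together. A partial recovery of that drop therefore seems the most reasonable expectation, with a rise beyond the scatter but smaller than the drop itself. The expected change is a 7.5-fold higher number from compound 3 to compound 4 (0.88 log units; beyond the scatter) as an estimate only. For compound 4 the estimated number is 1500 ng.h/mL in this assay with an expected range from 350 ng.h/mL to 7000 ng.h/mL as the likely span.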

Compound 4, area under the concentration-time curve: 2900 ng.h/mL
For compound 4 the middle estimate is 1.9-fold (0.29 log units) below the measured one; measured number inside the range.
By their numbers in this assay, from the lowest: compound 3; then compounds 1 and 4 (each within the scatter of the next); then compound 2.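

In this assay, a nitrile on this ring does not have to cost much: adding a cyano to the ring while the chloro stays gives a 5.2-fold lower number from compound 2 to compound 4 (0.71 log units; beyond the scatter), a modest step next to a 75-fold lower number from compound 2 to compound 3 (1.88 log units; beyond the scatter), where the chloro was lost. Moving from 2-cyanophenyl to 2-chloro-4-cyanophenyl on the double-bonded chain carbon gives a 15-fold higher number from compound 3 to compound 4 (1.16 log units; beyond the scatter), so a ring with both chloro and cyano stands far closer to the chloro-only compound than the cyano-only ring does. Nothing shown here explains why these rings differ so strongly in the amount of compound reaching the circulation.

The step to compound 4 adds a chloro and also puts the cyano at a different place on the ring, so the two changes cannot be separated without a ring that carries cyano alone at the place it holds in 2-chloro-4-cyanophenyl. On these data alone, it also remains open whether fluoro or methyl could stand in for the chloro on this ring and keep the number up.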